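The compounds below may be only part of what the source reports. "The series", "measured", "known", "first", "only" and "open" are said of these compounds alone.

Of the compounds shown here, three from this series have been tested in an assay on CHO cells for displacement of a labelled ligand from adenosine receptor A1 (Homo sapiens), read by scintillation counting, with a stated time of 120 min, tested at 1 uM (a higher number here means more inhibition at the concentration tested (going by the name of the read-out), a lower number less inhibition), and a fourth awaits its number.

Compound 1 `O=C(Nc1nc(-c2ccccc2)nc2cn(-c3ccccc3)nc12)c1ccco1` gives 11% in this assay. Compound 2 `O=C(c1ccco1)N(C(=O)c1ccco1)c1nc(-c2ccccc2)nc2cn(-c3ccccc3)nc12` carries a second (furan-2-yl)carbonyl on the same nitrogen, and in this assay compound 2 gives 3%. The two are related by a single change, (hydrogen in place of (furan-2-yl)carbonyl on an amide-type nitrogen), and the step it made was a number 8 percentage points higher from compound 2 to compound 1 (within the scatter), so the two numbers cannot be told apart.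

Compound 3 `COc1ccc(-n2cc3nc(C)nc(NC(=O)c4ccco4)c3n2)cc1` has a different core; how its core differs from that of compound 2 is not broken down here. In this assay compound 3 gives 6%, which sits within the scatter of both compound 1 and compound 2.

Compound 4 `COc1ccc(-n2cc3nc(C)nc(N)c3n2)cc1` is the unmeasured one. It differs from compound 3 by hydrogen in place of (furan-2-yl)carbonyl on a nitrogen on an aromatic ring. Within the data shown here, this is the same kind of change as the one from compound 2 to compound 1, but not the same: there the nitrogen was an amide-type nitrogen whose other neighbours are aromatic carbon and carbonyl carbon, whereas here it is a nitrogen on an aromatic ring whose other neighbours are aromatic carbon only.

The step from compound 3 to compound 4 is expected to be a number 2 percentage points higher from compound 3 to compound 4 (within the scatter), a small movement that rests on the earlier change having given a number 8 percentage points higher from compound 2 to compound 1 (within the scatter). Compound 4 is therefore estimated to give about 8% in this assay, most likely between 0% and 20%.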

Compound 4, a percentage reported as inhibition, at one concentration (the size of the read-out at that concentration, not a potency): 30%
Compound 4: middle estimate off by 22 percentage points, on the low side, and the stated range ends below it.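

In this assay, taking the (furan-2-yl)carbonyl off the nitrogen and leaving a plain amino group gave a number 24 percentage points higher from compound 3 to compound 4 (beyond the scatter). Among these compounds, this shows that the change does not carry over at one fixed size from one core to the other: the same change on two cores in this assay, a number 8 percentage points higher (within the scatter) from compound 2 to compound 1 and a number 24 percentage points higher (beyond the scatter) from compound 3 to compound 4, 16 percentage points apart, beyond the scatter of two such steps It does not show what sets the size, since there is only one pair on each core and the two nitrogens also differ: compound 1 keeps a (furan-2-yl)carbonyl on its nitrogen, whereas compound 4 has none left, so the core and the state of the nitrogen cannot be told apart as the source of the gap.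

The compounds shown leave open whether a plain amino group on the core of compound 1 would behave as it does in compound 4, which would compare the two cores directly. They also leave open whether the result for compound 4 depends on the bare amino group or only on the absence of the furan ring, a question that an acetyl or benzoyl group on that same nitrogen could help to settle.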